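Pyrrolyl for pyrimidinyl on the imidazoline ether series

A few compounds are considered here, and "the series" means these few. Any claim that something is new, unique, unknown or untested is made for them only; others in the source may bear on it.

Within the data shown here, compound 3 `c1cnc(-c2ccccc2OCC2=NCCN2)nc1` is the one member of the series whose result in a functional assay for activation of Alpha-1A adrenergic receptor (Homo sapiens), read by calcium flux (a lower number here means that less compound is needed, a higher number that more compound is needed for the effect), is a number, 1260 nM. Compound 1 `CCN(CC)C(=O)c1ccccc1OCC1=NCCN1` gives only a limit in this assay, < 5020 nM; this is the limit of < 5020 nM in this assay, at which 1 of the 3 values shown sits. Compound 2 `Cc1ccnc(-c2ccccc2OCC2=NCCN2)c1` also gives only a limit, < 100000 nM; this is the limit of < 100000 nM in this assay, at which 1 of the 3 values shown sits. Among the measured compounds shown here, neither limit can be set against the number for compound 3, so compound 3 stands alone as the reference point of the series and no measured step is available for comparison.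

Compound 4 `c1c[nH]c(-c2ccccc2OCC2=NCCN2)c1` is the untested member. It differs from compound 3 by 1H-pyrrol-2-yl in place of pyrimidin-2-yl on an aromatic carbon, which is 1H-pyrrol-2-yl in place of pyrimidin-2-yl on an aromatic carbon. For the measured compounds named here, nothing among the measured compounds shows what a change of this kind does in this assay, so the direction cannot be read from the data. The step from compound 3 to compound 4 is expected to lie within the usual scatter, a 1.3-fold lower number from compound 3 to compound 4 (0.10 log units; within the scatter), with a wide range to reflect that it rests on a single number. For compound 4 the expected result in this assay is 1000 nM, between 250 nM and 4000 nM.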

Compound 4, half-maximal effective concentration: 1.26 nM
The estimate for compound 4 lay 790-fold (2.90 log units) above the measured number, and the stated range ends above it.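

Among these compounds, on an aromatic carbon of the six-membered aromatic ring of carbon only, ortho to a group of 7 heavy atoms, 1H-pyrrol-2-yl in place of pyrimidin-2-yl gives a 1000-fold lower number from compound 3 to compound 4 (3.00 log units; beyond the scatter) in this assay, the first readable step and evidence that the result at this position depends heavily on which aromatic ring is attached. This single step changes several counted features together: a six-membered aromatic ring gives way to a five-membered one, the hetero atoms in the ring drop from two to one, and a hydrogen-bond donor enters while two hydrogen-bond acceptors leave. Nothing measured here bears on the cause of the step.

On these data alone, the steps involving the limits for compound 1 and compound 2 cannot be read, so the effect of the diethylamide or the methylpyridinyl group at this place remains unknown relative to compound 3 or compound 4. Also open, as far as these compounds go, is which changed feature matters: 1-methyl-1H-pyrrol-2-yl would remove the ring hydrogen on nitrogen while keeping the five-membered ring, and furan-2-yl or phenyl would test other ring types at this place.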